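A few compounds are considered here, and "the series" means these few. Any claim that something is new, unique, unknown or untested is made for them only; others in the source may bear on it.

In a functional assay on a cell-free system (plasma, Homo sapiens) for inhibition, with Plasma (Rattus norvegicus) as the target (a higher number here means a weaker inhibitor, a lower number a stronger inhibitor), compound 1 `O=c1cc(N2CCNCC2)oc2ccccc12` gives 56000 nM, compound 2 `O=c1cc(N2CCNCC2)c2ccc(OCc3cccnc3)cc2o1` gives 21300 nM, and compound 3 `COc1c(C)cnc(COc2ccc3c(N4CCNCC4)cc(=O)oc3c2C)c1C` gives 3300 nM. Compound 3 thus has the lowest number of the three, beyond the scatter from both others. Compound 4 `CSCCOc1ccc2c(N3CCNCC3)cc(=O)oc2c1C` carries (methylsulfanyl)methyl in place of 4-methoxy-3,5-dimethylpyridin-2-yl on a saturated chain carbon bound to an oxygen on an aromatic ring. For the measured compounds named here, no measured pair isolates this change, so the expectation rests on the three values alone. Compound 1, with no such ring-bearing chain, stands at 56000 nM, which points towards a weaker inhibitor. The expected step, a rise beyond the scatter, is a 4.5-fold higher number from compound 3 to compound 4 (0.66 log units; beyond the scatter). For compound 4 the estimate is 15000 nM, with an expected range of 5000 nM to 45000 nM.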

Compound 4, half-maximal inhibitory concentration: 1500 nM
The estimate for compound 4 lay 10-fold (1.00 log units) above the measured number; measured number below the stated range.
By their numbers in this assay, from the lowest: compound 4; then compound 3; then compound 2; then compound 1.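

In this assay, (methylsulfanyl)methyl in place of 4-methoxy-3,5-dimethylpyridin-2-yl on a saturated chain carbon bound to an oxygen on an aromatic ring gives a 2.2-fold lower number from compound 3 to compound 4 (0.34 log units; beyond the scatter) and is a modest step. For the compounds shown here, at this place, then, the six-membered aromatic ring of the leaving group is not needed for the lowest number so far, and a group with no ring serves in its place. No measurement at hand accounts for this step. Open, on these data alone, is whether the sulfur or the loss of the ring goes with the lower number; methoxymethyl, a longer chain or an amine on this carbon would separate the two.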